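The source may hold more compounds than are shown below. What is called first, only, known or untested is meant among the compounds shown, and "the series" means these compounds.

Measured in a functional assay on SH-SY5Y cells (Homo sapiens) for cytotoxicity, with a stated time of 24 h; on this read-out higher numbers stand for weaker inhibition and lower numbers for stronger inhibition:
- compound 1 `CC1=Cc2c(cc(C)oc2=O)OC1C`: 200000 nM
- compound 2 `CCCCCCCCC1C=Cc2c(cc(C)oc2=O)O1`: 76000 nM

Compound 1 holds the higher of the two numbers, so it is the weaker inhibitor here, and compound 2 lies below it by more than the usual scatter. Compound 3 `CC1=Cc2c(cc(C)oc2=O)OC1c1ccco1` has furan-2-yl in place of methyl on a saturated ring carbon. Going by the values given here, no measured pair shows this change, so the expectation in this assay is only a small move towards a lower number, perhaps none beyond the scatter. The expected size is a 1.8-fold lower number from compound 1 to compound 3 (0.26 log units; within the scatter). For compound 3 the estimated value is 110000 nM, with a range of 40000 nM to 300000 nM.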

Compound 3, half-maximal inhibitory concentration: 49000 nM
For compound 3 the middle estimate is 2.2-fold (0.35 log units) above the measured one, and the stated range covers the measured number.
By their numbers in this assay, from the lowest: compounds 3 and 2 (each within the scatter of the next); then compound 1.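

Furan-2-yl in place of methyl on the saturated ring carbon next to the ring oxygen gives a 4.1-fold lower number from compound 1 to compound 3 (0.61 log units; beyond the scatter) in this assay and so shows that the number responds to the group at this carbon. Going by these compounds alone, no earlier pair could show this, since none differed in one place only. Nothing measured here explains the step.

Whether the furan oxygen matters stays open, since phenyl, which would test this, is not among the compounds shown. So does the effect of an amine or a longer chain at this carbon.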